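A new aryl group for compound 3 on the doubly bonded carbon

This account rests on a few compounds, and the source may have more. Where it says the series, first, only, none or still open, it means among the compounds named here.

Of the compounds shown here, three with a shared core have been measured in a functional assay on A549 cells (Homo sapiens) for inhibition, read by MTT assay, with a stated time of 72 h; on this read-out higher numbers stand for weaker inhibition and lower numbers for stronger inhibition. Compound 1 `CNc1nc(C)c(C(=O)N/N=C/c2cccc(C(F)(F)F)c2)s1` gives only a limit of the assay in this assay: > 100 ug/mL. Compound 2 `CN(C(=O)NC(=O)c1cccc(C(F)(F)F)c1)c1nc(C(F)(F)F)c(C(=O)N/N=C/c2ccccc2C(F)(F)F)s1` gives 12.1 ug/mL in this assay. Compound 3 `CN(C(=O)NC(=O)c1ccc(F)c(F)c1)c1nc(C(F)(F)F)c(C(=O)N/N=C/c2ccccc2C(F)(F)F)s1` gives 6.96 ug/mL in this assay; its number is the lower of the two shown, but the step of a 1.7-fold lower number from compound 2 to compound 3 (0.24 log units; within the scatter) lies within the scatter, so the two cannot be told apart. That step exchanges the aryl group on the carbonyl carbon.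

Compound 4 `CN(C(=O)NC(=O)c1ccc(F)c(F)c1)c1nc(C(F)(F)F)c(C(=O)N/N=C/c2ccc([N+](=O)[O-])cc2)s1` differs from compound 3 at a different place: 4-nitrophenyl in place of 2-(trifluoromethyl)phenyl on a carbon with a double bond to nitrogen. For the measured compounds named here, no measured step touches this position; the only measured step, a 1.7-fold lower number from compound 2 to compound 3 (0.24 log units; within the scatter), sits on the carbonyl side and was within the scatter, so it says little about the carbon bound to nitrogen. Without a comparable step, the expectation is of no change beyond the scatter, held with a wide range. Compound 4 is therefore expected to give about 7 ug/mL in this assay, between 2 ug/mL and 30 ug/mL. The expected step is a 1.0-fold higher number from compound 3 to compound 4 (0.00 log units; within the scatter).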

Compound 4, half-maximal inhibitory concentration: 5.78 ug/mL
Beside the measured number, compound 4's estimate is 1.2-fold (0.08 log units) above it; low and high end bracket the measured number.
By their numbers in this assay, from the lowest: compounds 4, 3 and 2 (each within the scatter of the next, the first and the last beyond it). At a limit, above all of these: compound 1.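

For the compounds shown here, this is the first measured change on the carbon with a double bond to nitrogen, and in this assay it gives a 1.2-fold lower number from compound 3 to compound 4 (0.08 log units; within the scatter). The two compounds cannot be told apart, so this pair shows that 2-(trifluoromethyl)phenyl and 4-nitrophenyl, two aryl groups with quite different substituents, can be exchanged here without the read-out moving beyond the usual scatter. Nothing shown gives a reason for this result.

On these data alone, both groups are six-membered aromatic rings of carbon only, so it remains open whether this carbon would carry a plain alkyl chain or a ring bearing an amine or a carboxylic acid equally well. A single pair also cannot say whether the same exchange would read alike with a different aryl group on the carbonyl side.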